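Working notes on the triazolylmethyl aryl series

A few compounds are considered here, and "the series" means these few. Any claim that something is new, unique, unknown or untested is made for them only; others in the source may bear on it.

Compound 3 `N#CC1=C(N)Oc2c(N)cc3nc4ccccc4nc3c2C12C(=O)N(Cc1cnnn1-c1cc(Cl)ccc1Cl)c1ccccc12` carries a 2,5-dichlorophenyl on an aromatic nitrogen of the shared core. In an ADME assay on HUVEC cells (Homo sapiens) for antiproliferative activity, read by MTT assay, with a stated time of 48 h (a lower number here means a stronger inhibitor, a higher number a weaker inhibitor), compound 3 reaches only a limit of the assay, > 50000 nM. Compound 1 `N#CC1=C(N)Oc2c(N)cc3nc4ccccc4nc3c2C12C(=O)N(Cc1cnnn1-c1ccccc1Br)c1ccccc12`, with a 2-bromophenyl on that aromatic nitrogen, gives 34200 nM in this assay. Compound 2 `Cc1ccc(C)c(-n2nncc2CN2C(=O)C3(C(C#N)=C(N)Oc4c(N)cc5nc6ccccc6nc5c43)c3ccccc32)c1`, bearing a 2,5-dimethylphenyl there, likewise ends at a limit rather than a number, > 50000 nM. The measured steps are therefore an at least 1.4-fold higher number from compound 1 to compound 2 (0.16 log units; that floor lies within the scatter) and an at least 1.4-fold higher number from compound 1 to compound 3 (0.16 log units; that floor lies within the scatter), while between the two limits the step is a step that the two limits leave unreadable from compound 2 to compound 3. The common feature of the set is the limit of > 50000 nM in this assay, at which 2 of the 3 values shown sit, so compound 3 stands with compound 2 at the weak end of what this series has shown, and compound 1 is the only member with a number.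

Compound 4 `N#CC1=C(N)Oc2c(N)cc3nc4ccccc4nc3c2C12C(=O)N(Cc1cnnn1-c1ccc(F)c(Cl)c1)c1ccccc12` is the next variation: 3-chloro-4-fluorophenyl in place of 2,5-dichlorophenyl on an aromatic nitrogen. No measured step exchanges one of the shown aryl groups for a 3-chloro-4-fluorophenyl, so none bears directly on it; the two steps that leave compound 1 both run toward the limit, and the step from compound 2 to compound 3 cannot be read. The expectation is therefore no change beyond the scatter, a number no higher from compound 3 to compound 4 (the limit leaves the size open), with a strong chance that only a limit is reported again. Compound 4 is estimated at 50000 nM, within a range of 20000 nM to 150000 nM.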

Compound 4, half-maximal inhibitory concentration: > 50000 nM
Compound 4 gave a limit, no number; the forecaster's own chance of this, stated with the estimate: 70%; the middle value lies on the limit itself.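

Compound 4 adds a third substitution pattern at this position, on the aromatic nitrogen of the five-membered ring, and it also ends at a limit of this assay, so replacing 2,5-dichlorophenyl with 3-chloro-4-fluorophenyl, which brings in fluorine, gives no number to set against compound 3. The steps among compound 2, compound 3 and compound 4 cannot be read, and the only readable step is an at least 1.4-fold higher number from compound 1 to compound 4 (0.16 log units; that floor lies within the scatter), so even compound 1 is not shown to differ from compound 4 beyond the scatter. Dimethyl, dichloro and chloro-fluoro phenyl groups now share one outcome, with compound 1 the only member that goes against it by giving a number: the limit of > 50000 nM in this assay, at which 3 of the 4 values shown sit.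

The compounds shown leave open whether any group at this position can bring the value in this assay clearly under the limit, for example a phenyl carrying a carboxylic acid or an amine, or a longer chain in place of the phenyl. They also leave open how compound 2, compound 3 and compound 4 rank among themselves, and whether any of them truly differs from compound 1.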